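The source may hold more compounds than are shown below. What is called first, only, known or untested is meant among the compounds shown, and "the series" means these compounds.

Measured compounds:
compound 1 `CCCCCCOC(=O)/C=C/c1ccc(NC(=O)C2(NC(=O)c3ccc4c(C5CCCC5)c(-c5ncc(Cl)cn5)n(C)c4c3)CCC2)cc1OCC`: 17.9 h
compound 2 `CCOc1cc(NC(=O)C2(NC(=O)c3ccc4c(C5CCCC5)c(-c5ncc(Cl)cn5)n(C)c4c3)CCC2)ccc1/C=C/C(=O)OCCOc1ccccc1`: > 5 h
compound 3 `CCOc1cc(NC(=O)C2(NC(=O)c3ccc4c(C5CCCC5)c(-c5ncc(Cl)cn5)n(C)c4c3)CCC2)ccc1/C=C/C(=O)OCC(=O)OCc1ccc(Cl)cc1`: 5.62 h

Of the compounds shown here, three sharing one core have been measured in an ADME assay (liver) for pharmacokinetics, with Liver microsome (Homo sapiens) as the target, using microsomes; on this read-out lower numbers stand for a shorter-lived compound and higher numbers for a longer-lived compound. Compound 1 gives 17.9 h, the highest of the two numbers. Compound 3 gives 5.62 h, and the change from the pentyl of compound 1 to the ((4-chlorobenzyl)oxy)carbonyl of compound 3 on a saturated chain carbon bound to an oxygen next to a carbonyl group brings a 3.2-fold lower number from compound 1 to compound 3 (0.50 log units; beyond the scatter). For compound 2 the result is a limit, not a number (the limit of > 5 h in this assay, at which 1 of the 3 values shown sits), so the steps a step that the limit leaves unreadable from compound 1 to compound 2 and a step that the limit leaves unreadable from compound 2 to compound 3 cannot be sized.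

Compound 4 `CCOc1cc(NC(=O)C2(NC(=O)c3ccc4c(C5CCCC5)c(-c5ncc(Cl)cn5)n(C)c4c3)CCC2)ccc1/C=C/C(=O)OCC(=O)N1CCOCC1` has not yet been measured. It differs from compound 1 as follows: (morpholin-4-yl)carbonyl in place of pentyl on a saturated chain carbon bound to an oxygen next to a carbonyl group. The step from compound 1 to compound 3 is the only readable one at this position, and it exchanged pentyl for another carbonyl-bearing group with a modest lowering. On that basis a lowering of similar size is expected for compound 4, although the morpholine ring is not represented among the measured compounds. Compound 4 is therefore estimated at 7 h, within the range 3 h to 15 h, an expected step of a 2.6-fold lower number from compound 1 to compound 4 (0.41 log units; beyond the scatter).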

Compound 4, half-life: 0.667 h
The estimate for compound 4 lay 10-fold (1.02 log units) above the measured number, outside the stated range (below it).
By their numbers in this assay, from the lowest: compound 4; then compound 3; then compound 1.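

In this assay the place on a saturated chain carbon bound to an oxygen next to a carbonyl group proves far more sensitive than compound 3 alone suggested: (morpholin-4-yl)carbonyl in place of pentyl brings a 27-fold lower number from compound 1 to compound 4 (1.43 log units; beyond the scatter). The two carbonyl-bearing groups do not act alike, since morpholin-4-yl in place of (4-chlorobenzyl)oxy on a carbonyl carbon still brings an 8.4-fold lower number from compound 3 to compound 4 (0.93 log units; beyond the scatter), so a carbonyl at this place does not by itself set the number and the group on that carbonyl carbon changes it too. The (morpholin-4-yl)carbonyl also stands apart from the phenoxymethyl, with an at least 7.4-fold lower number from compound 2 to compound 4 (0.87 log units; beyond the scatter).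

On these data alone, the remaining steps to compound 2 cannot be read, and compound 2 stands only as a limit, so its order relative to compound 1 and compound 3 stays open: the limit of > 5 h in this assay, at which 1 of the 4 values shown sits. Whether an amide of a simple amine such as dimethylamine, or a carboxylic acid, at this place would give as low a number also stays open, and nothing shown gives a reason for the fall.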